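The source may report more compounds than this note shows. Statements on the series, on what has been measured and on what is new or still open speak of the compounds shown alone.

In a functional assay on LN-229 cells (Homo sapiens) for inhibition, read by MTT assay, with a stated time of 72 h (on this read-out higher numbers stand for weaker inhibition and lower numbers for stronger inhibition), the measured compounds stand as follows:

Compound 1 `CCCNc1cc(-c2ccccc2)nc2cc(OC)cc(OC)c12`: 1820 nM
Compound 2 `CCCCNc1cc(-c2ccccc2)nc2cc(OC)cc(OC)c12`: 3920 nM
Compound 3 `COc1cc(OC)c2c(N3CCCCC3)cc(-c3ccccc3)nc2c1`: 66000 nM

Compound 3 gives the highest number of the three, and both steps leading to it are large: a 36-fold higher number from compound 1 to compound 3 (1.56 log units; beyond the scatter) and a 17-fold higher number from compound 2 to compound 3 (1.23 log units; beyond the scatter). In each of those steps the hydrogen-bond donor of the amino group was lost.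

Compound 4 `COc1cc(OC)c2c(NC3CCCCC3)cc(-c3ccccc3)nc2c1` differs from compound 3 by cyclohexylamino in place of piperidin-1-yl on an aromatic carbon. This change brings a hydrogen-bond donor back, so the two large steps into compound 3 bear on it directly, though in the opposite direction. A large downward step in this assay is therefore expected. The expected step is a 17-fold lower number from compound 3 to compound 4 (1.22 log units; beyond the scatter). Compound 4 is estimated at 4000 nM, with a range from 1500 nM to 12000 nM.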

Compound 4, half-maximal inhibitory concentration: 6080 nM
Compound 4: middle estimate off by 1.5-fold (0.18 log units), on the low side; measured number inside the range.
By their numbers in this assay, from the lowest: compound 1; then compounds 2 and 4 (each within the scatter of the next); then compound 3.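

With a six-membered ring kept at this aromatic carbon, the change to cyclohexylamino gives an 11-fold lower number from compound 3 to compound 4 (1.04 log units; beyond the scatter), so a ring here does not by itself go with the high number of compound 3. Cyclohexyl on the nitrogen gives a 1.6-fold higher number from compound 2 to compound 4 (0.19 log units; within the scatter) against butyl, and a 3.3-fold higher number from compound 1 to compound 4 (0.52 log units; beyond the scatter) against propyl, a modest step. Nothing measured here explains these steps.

From the compounds shown here alone, whether the hydrogen on the nitrogen or the different ring carries the step from piperidin-1-yl remains open; methyl(cyclohexyl)amino would separate the two. Going by these compounds, how cyclopentylamino or morpholin-4-yl would stand at this carbon is also open.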